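A few compounds are considered here, and "the series" means these few. Any claim that something is new, unique, unknown or untested is made for them only; others in the source may bear on it.

Among the compounds with values here, compound 2, `C[C@H](NC(=O)CN(c1ncnc2c1ncn2C1CCCCO1)C1CC1)C(=O)OCc1ccccc1`, gives 6.01% in a functional assay on the whole organism (Tail, strain ICR) with Mus musculus as the target, in the tail flick test, with a stated time of 150 min, at a dose of 25 umol/kg by the oral route (a higher number here means a stronger effect of the compound at the dose given, a lower number a weaker effect), and stands lowest of the two numbers measured so far. Within the data shown here, its nearest neighbour is compound 1, `O=C(CN(c1ncnc2c1ncn2C1CCCCO1)C1CC1)N[C@@H](CO)C(=O)OCc1ccccc1`, which in this assay gives 18.3%; the single step of a number 12.3 percentage points lower from compound 1 to compound 2 (beyond the scatter) is the only comparison on record at this position on the chain. Compound 3, `CSCC[C@H](NC(=O)CN(c1ncnc2c1ncn2C1CCCCO1)C1CC1)C(=O)OCc1ccccc1`, has not yet been measured in this assay. It differs from compound 2 by (methylsulfanyl)methyl in place of hydrogen on a saturated chain carbon, two bonds along the chain from an amide-type nitrogen and a carbonyl carbon. That one measured step shows that replacing a hydroxy with hydrogen at this place costs a modest amount; it does not show what a (methylsulfanyl)methyl group, with its one hydrogen-bond acceptor and no donor, will do in place of the hydrogen. Among the measured compounds shown here, no measured pair speaks directly to this change, so a step of either sign is possible, and he expects one that is at most modest. His estimate for compound 3 is 11%, with a range from 0% to 28%, which would mean a step of a number 5 percentage points higher from compound 2 to compound 3 (within the scatter), to be judged against the result when it arrives.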

Compound 3, a percentage reported as activity, at one dose (the size of the read-out at that dose, not a potency): 17.5%
Compound 3: middle estimate off by 6.5 percentage points, on the low side; the measured number falls inside the stated range.
By their numbers in this assay, from the lowest: compound 2; then compounds 3 and 1 (each within the scatter of the next).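

With a number 11.5 percentage points higher from compound 2 to compound 3 (beyond the scatter), the place on a saturated chain carbon, two bonds along the chain from an amide-type nitrogen and a carbonyl carbon, proves able to take a group other than hydroxy and still read clear of the plain hydrogen of compound 2. The step of a number 0.8 percentage points lower from compound 1 to compound 3 (within the scatter) then sets hydroxy and (methylsulfanyl)methyl on a level here, so the drop seen on going from compound 1 to compound 2 does not belong to the hydroxy group alone, and among these three compounds only the one carrying hydrogen stands apart. Nothing measured here explains why the two groups read alike.

The compounds shown do not tell whether the sulfur of the (methylsulfanyl)methyl group counts for anything, which a plain alkyl chain of the same length or a methoxymethyl group in its place would test. They also leave open how an amine or a carboxylic acid would read at this place, and whether any group here can rise beyond the level shared by compound 1 and compound 3 in this assay.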